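The source may report more compounds than this note shows. Statements on the series, on what has been measured and on what is new or still open speak of the compounds shown alone.

Measured compounds:
compound 1 `COC(=O)[C@@]1(C)CC[C@@H]2C3=C1CC[C@@H](C)[C@]3(C)C[C@@H]1c3ccccc3N[C@H]21`, 50000 nM
compound 2 `COC(=O)[C@@]1(C)CC[C@@H]2C3=C1CC[C@@H](C)[C@]3(C)C[C@@H]1c3cc(Br)ccc3N[C@H]21`, 55000 nM
compound 3 `COC(=O)[C@@]1(C)CC[C@@H]2C3=C1CC[C@@H](C)[C@]3(C)C[C@@H]1c3cc(F)ccc3N[C@H]21`, 32000 nM

Of the compounds shown here, three sharing one core have been tested in a functional assay on WiDr cells (Homo sapiens) for inhibition, read by sulforhodamine B assay, with a stated time of 48 h; a lower number here means a stronger inhibitor of growth, a higher number a weaker inhibitor of growth. Compound 1 gives 50000 nM in this assay and sits in the middle of the three numbers: compound 2 is its nearest neighbour, with a 1.1-fold higher number from compound 1 to compound 2 (0.04 log units; within the scatter), and compound 3 its furthest, with a 1.6-fold lower number from compound 1 to compound 3 (0.19 log units; within the scatter). Compound 2 and compound 3 themselves differ by a 1.7-fold lower number from compound 2 to compound 3 (0.24 log units; within the scatter). All three steps lie within the scatter, so the three numbers cannot be put in order.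

Compound 4 `COC(=O)[C@@]1(C)CC[C@@H]2C3=C1CC[C@@H](C)[C@]3(C)C[C@@H]1c3cccc(Cl)c3N[C@H]21` is not yet measured. It differs from compound 1 by chloro in place of hydrogen on an aromatic carbon. The two measured steps that bear on this change are the halogen-for-hydrogen substitutions on an aromatic carbon, from compound 1 to compound 2 and from compound 1 to compound 3, both within the scatter. Nothing in the measured compounds speaks for a step beyond the scatter in this assay, and so compound 4 is expected to show a number close to that of compound 1, an estimated step of a 1.1-fold lower number from compound 1 to compound 4 (0.05 log units; within the scatter). The estimate for compound 4 is 45000 nM, with a range from 20000 nM to 100000 nM.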

Compound 4, concentration for 50% growth inhibition: 67000 nM
Estimate against measurement, compound 4: 1.5-fold (0.17 log units) below; low and high end bracket the measured number.
By their numbers in this assay, from the lowest: compounds 3, 1, 2 and 4 (each within the scatter of the next, the first and the last beyond it).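

In this assay, chloro in place of hydrogen on an aromatic carbon ortho to a fused ring and meta to a fused ring gives a 1.3-fold higher number from compound 1 to compound 4 (0.13 log units; within the scatter) and so leaves the number of compound 1 unchanged within the usual scatter. This extends the picture from bromo in compound 2 and fluoro in compound 3, which sit on another carbon of the same aromatic ring, to a third halogen and a second ring carbon: none of the three single halogen-for-hydrogen changes shown on this ring produces a step beyond the scatter. No measurement accompanying these compounds offers any explanation for this flat result.

From the compounds shown here alone, it remains open whether a group other than a halogen, such as an amine, a methoxy group or a carboxylic acid, would produce a step beyond the scatter on this aromatic carbon. The compounds shown also leave open whether chloro would read the same on the carbon that carries bromo in compound 2, and whether replacing the methyl ester of the shared core with a carboxylic acid or an amide would change the number at all.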